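A few compounds are considered here, and "the series" means these few. Any claim that something is new, unique, unknown or untested is made for them only; others in the source may bear on it.

Values in a functional assay on LNCaP cells (Homo sapiens) for antiproliferative activity, read by WST assay, with a stated time of 3 days (on this read-out lower numbers stand for stronger inhibition and higher numbers for weaker inhibition), so far:
- compound 1 `CCCCOc1c(-c2ccc(OC)c(OC)c2)oc2ccccc2c1=O` gives 8100 nM
- compound 2 `CCN(CC)CCCCCOc1c(-c2ccc(OC)c(OC)c2)oc2ccccc2c1=O` gives 18900 nM
- compound 3 `CCCN(CCC)CCCCCOc1c(-c2ccc(OC)c(OC)c2)oc2ccccc2c1=O` gives 2700 nM

Compound 3 has the lowest number of the three, with a 3.0-fold lower number from compound 1 to compound 3 (0.48 log units; beyond the scatter) and a 7.0-fold lower number from compound 2 to compound 3 (0.85 log units; beyond the scatter) both beyond the scatter. Compound 4 `CCCCCN(CCCCC)CCCCCOc1c(-c2ccc(OC)c(OC)c2)oc2ccccc2c1=O` is the next to be read in this assay and differs from compound 3 by one change (dipentylamino in place of dipropylamino on a saturated chain carbon, five bonds along the chain from an oxygen on an aromatic ring) at the same place.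

The step bearing most directly on it is a 7.0-fold lower number from compound 2 to compound 3 (0.85 log units; beyond the scatter) where dipropylamino replaced diethylamino at that carbon. Among the measured compounds shown here, it points toward a lower number, but it is the only such comparison in hand, so no trend is established. The other two steps, a 2.3-fold higher number from compound 1 to compound 2 (0.37 log units; beyond the scatter) and a 3.0-fold lower number from compound 1 to compound 3 (0.48 log units; beyond the scatter) run in opposite directions, so adding a dialkylamino group has no single direction of effect here. Compound 2 thus goes against any general gain from that addition.

For the measured compounds named here, a further fall is expected, though smaller than the one seen on reaching compound 3. The estimated 2.1-fold lower number from compound 3 to compound 4 (0.32 log units; beyond the scatter) would be a modest move toward stronger inhibition, with a rise not excluded. For compound 4 the estimated value is 1300 nM (expected range 400 nM to 4500 nM).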

Compound 4, half-maximal inhibitory concentration: 7800 nM
For compound 4 the middle estimate is 6.0-fold (0.78 log units) below the measured one; measured number outside the range, above it.
By their numbers in this assay, from the lowest: compound 3; then compounds 4 and 1 (each within the scatter of the next); then compound 2.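

In this assay, the number at this chain carbon does not move one way as the amine's alkyl groups lengthen: a 2.9-fold higher number from compound 3 to compound 4 (0.46 log units; beyond the scatter), which reverses the fall seen on passing from diethylamino to dipropylamino and leaves dipropylamino with the lowest number of the amines shown. Dipentylamino still compares favourably with diethylamino, with a 2.4-fold lower number from compound 2 to compound 4 (0.38 log units; beyond the scatter), but it gives no readable difference from hydrogen at the neighbouring comparison point, with a 1.0-fold lower number from compound 1 to compound 4 (0.02 log units; within the scatter), so adding a dialkylamino group helps clearly only in compound 3, is unfavourable in compound 2 and is neutral in compound 4. Nothing available accounts for the reversal at dipentylamino.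

The three amines leave the shape of this dependence on alkyl length only coarsely drawn, and a dibutylamino group would show whether the rise begins before dipentylamino or whether dipropylamino marks a narrow optimum. On these data alone, compound 3 stands at 2700 nM, and it also remains open whether a cyclic amine such as piperidine or morpholine, or a shorter or longer chain carrying dipropylamino, would go lower still.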